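Replacing Trifluoromethyl with Isopropyl: Expectation for Compound 4

The source may report more compounds than this note shows. Statements on the series, on what has been measured and on what is new or still open speak of the compounds shown alone.

Of the compounds shown here, three have been measured in an assay on HEK293 cells for binding affinity to 5-hydroxytryptamine receptor 7 (Homo sapiens), read by radioligand binding; on this read-out higher numbers stand for weaker inhibition and lower numbers for stronger inhibition. Compound 1 `Brc1ccc2ccn(CCN3CCCN4CCCCC4C3)c2c1` gives 3 nM, compound 2 `CN1CCCN(CCn2ccc3cc(Br)ccc32)CC1` gives 88 nM, and compound 3 `CN1CCCN(CCn2ccc3ccc(C(F)(F)F)cc32)CC1` gives 23 nM. Among these three numbers compound 3 stands second highest: its nearest neighbour is compound 2, whose number is higher by an amount beyond the usual scatter, while compound 1 lies furthest away, with a lower number that also lies beyond the scatter.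

Compound 4 `CC(C)c1ccc2ccn(CCN3CCCN(C)CC3)c2c1` has not yet been measured. It differs from compound 3 in one place: isopropyl in place of trifluoromethyl on an aromatic carbon. Among the measured compounds shown here, no two measured compounds differ only in this exchange, so the size of such a step is untested here. Both groups lack hydrogen-bond donors and acceptors and carry no net charge. Compound 3 gives 23 nM in this assay. From there the step of a 1.3-fold higher number from compound 3 to compound 4 (0.12 log units; within the scatter) is expected to be small, possibly no larger than the scatter, with a slight lean toward a weaker number. For compound 4 the estimate in this assay is 30 nM, with a likely range from 8 nM to 120 nM.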

Compound 4, inhibition constant: 145 nM
Beside the measured number, compound 4's estimate is 4.8-fold (0.68 log units) below it; measured number above the stated range.
By their numbers in this assay, from the lowest: compound 1; then compound 3; then compounds 2 and 4 (each within the scatter of the next).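

The position on the six-membered aromatic ring clearly responds to which group it carries: in this assay, isopropyl in place of trifluoromethyl gives a 6.3-fold higher number from compound 3 to compound 4 (0.80 log units; beyond the scatter), with the rest of the molecule unchanged. Trifluoromethyl and isopropyl both have no hydrogen-bond donors or acceptors and no net charge, yet they do not read out alike here. Those shared counts are therefore not enough to predict the result of an exchange at this position.

Going by these compounds, whether a methoxy group, a nitrile or a plain hydrogen here would give a number closer to compound 3 or to compound 4 remains open, as does whether the same exchange would give a step of this size on the core of compound 1. No measured property of these two groups is available to explain the step.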